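A few compounds are considered here, and "the series" means these few. Any claim that something is new, unique, unknown or untested is made for them only; others in the source may bear on it.

Measured so far in an assay on HEK293T cells for inhibition of nuclear factor NF-kappa-B complex (Homo sapiens), read by a luciferase reporter; on this read-out higher numbers stand for weaker inhibition and lower numbers for stronger inhibition:
compound 1 `COc1cc2c(c(O)c1C(=O)/C=C/c1ccc(OC(=O)c3cccc(Cl)c3)cc1)CCC(C)(C)O2` — a limit of > 30000 nM
compound 2 `COc1cc2c(c(O)c1C(=O)/C=C/c1ccc(OC(=O)c3ccc(OC(F)(F)F)cc3)cc1)CCC(C)(C)O2` — a limit of > 30000 nM

On the numbers shown, compound 2 stands at a limit of > 30000 nM, not at a number. Compound 3 `COc1cc2c(c(O)c1C(=O)/C=C/c1ccc(OC(=O)c3cccc(Br)c3)cc1)CCC(C)(C)O2` differs from compound 2 by 3-bromophenyl in place of 4-(trifluoromethoxy)phenyl on a carbonyl carbon. Going by the values given here, the only measured step, a step that the two limits leave unreadable from compound 1 to compound 2, cannot be read, since both of its compounds sit at the limit of > 30000 nM in this assay, at which 2 of the 2 values shown sit. Among the compounds with values here, no measured step therefore fixes an expected size or direction in this assay, and compound 3 is likely to return a limit as well. Compound 3 is estimated at 40000 nM, range 12000 nM to 150000 nM. The expected step is a step that the limit leaves unreadable from compound 2 to compound 3.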

Compound 3, half-maximal inhibitory concentration: > 30000 nM
Compound 3: a limit, no number; the forecaster's own chance of this, stated with the estimate: 85%; the middle value lies beyond the limit too.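

Compound 3 also gives only a limit in this assay, so no step among compound 1, compound 2 and compound 3 can be read: the limit of > 30000 nM in this assay, at which 3 of the 3 values shown sit.

The compounds shown leave open how 3-chlorophenyl, 4-(trifluoromethoxy)phenyl and 3-bromophenyl rank against one another.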